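Limit-only cytotoxicity notes on a diamino-quinoxaline pair

The source may report more compounds than this note shows. Statements on the series, on what has been measured and on what is new or still open speak of the compounds shown alone.

Compound 1 `Nc1cc(N)c2nc(-c3ccccc3)c(Oc3ccc(Cl)c(Cl)c3)nc2c1` has been tested in a functional assay on A498 cells (Homo sapiens) for inhibition, read by sulforhodamine B assay, with a stated time of 48 h (on this read-out higher numbers stand for lower toxicity in this test and lower numbers for higher toxicity in this test), where compound 1 gives only a limit, < 100000 nM, and no number. Compound 2 `CCOC(=O)[C@H](CCC(=O)O)NC(=O)c1ccc(CNc2nc3cc(N)cc(N)c3nc2-c2ccccc2)cc1` likewise returns a limit in this assay, < 100000 nM. Both values sit at the limit of < 100000 nM in this assay, at which 2 of the 2 values shown sit, so compound 1 cannot be placed relative to anything else. Compound 3 `Nc1cc(N)c2nc(-c3ccccc3)c(NCc3ccc(F)cc3)nc2c1` differs by (4-fluorobenzyl)amino in place of 3,4-dichlorophenoxy on an aromatic carbon. Among the compounds with values here, with no measured step to lean on, the change from compound 1 to compound 3 is expected to be a step that the limit leaves unreadable from compound 1 to compound 3, no more than the scatter. Compound 3 is estimated at 30000 nM, between 5000 nM and 100000 nM.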

Compound 3, concentration lethal to 50% of the cells: 57500 nM
Compound 3: middle estimate off by 1.9-fold (0.28 log units), on the low side; the measured number falls inside the stated range.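

No step can be read from compound 1 to compound 3, because compound 1 gives only a limit: the limit of < 100000 nM in this assay, at which 2 of the 3 values shown sit.

The compounds shown leave open how compound 1 and compound 2 truly stand against compound 3 in this assay.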